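The compounds below may be only part of what the source reports. "The series", "measured", "known", "first", "only" and "open" are said of these compounds alone.

Working notes on the series.

Among the measured compounds shown here, compound 2 `NS(=O)(=O)NCC1CCN(c2cc(-c3ccc(Cl)cc3)ncn2)CC1` gives 25500 nM in a functional assay on MCF7 cells (Homo sapiens) for antiproliferative activity, read by sulforhodamine B assay, with a stated time of 48 h (on this read-out higher numbers stand for weaker inhibition of growth and lower numbers for stronger inhibition of growth), the highest of the three numbers so far, but its gap to compound 1 `CCCCc1ccc(-c2cc(N3CCC(CNS(N)(=O)=O)CC3)ncn2)cc1` at 21800 nM and to compound 3 `COC(=O)c1ccc(-c2cc(N3CCC(CNS(N)(=O)=O)CC3)ncn2)cc1` at 17700 nM is within the scatter in each case. The three measured steps, a 1.2-fold higher number from compound 1 to compound 2 (0.07 log units; within the scatter), a 1.2-fold lower number from compound 1 to compound 3 (0.09 log units; within the scatter) and a 1.4-fold lower number from compound 2 to compound 3 (0.16 log units; within the scatter), all exchange the group on the aromatic carbon of the pendant phenyl and none moves the number beyond the scatter.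

Compound 4 `NS(=O)(=O)NCC1CCN(c2cc(-c3ccccc3F)ncn2)CC1` is not yet measured. It differs from compound 2 by 2-fluorophenyl in place of 4-chlorophenyl on an aromatic carbon. For the measured compounds named here, no measured step exchanges the whole aryl group or places a halogen on the 2-position of the phenyl, so the bearing of the three steps is indirect: they show only that changes on this phenyl have left this assay flat across compounds 1, 2 and 3. On that basis no step beyond the scatter is expected, a 1.1-fold lower number from compound 2 to compound 4 (0.03 log units; within the scatter). Compound 4 is therefore estimated at 24000 nM, with a range of 9000 nM to 65000 nM.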

Compound 4, concentration for 50% growth inhibition: 48500 nM
Compound 4: the middle estimate sits 2.0-fold (0.31 log units) below what was measured, within the range that was stated.
By their numbers in this assay, from the lowest: compounds 3, 1, 2 and 4 (each within the scatter of the next, the first and the last beyond it).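

In this assay, 2-fluorophenyl in place of 4-chlorophenyl gives a 1.9-fold higher number from compound 2 to compound 4 (0.28 log units; within the scatter) and so adds a change of the whole aryl group, halogen and its place together, that still stays within the scatter. The values of compound 3 at 17700 nM and compound 4 at 48500 nM nevertheless lie beyond the scatter of each other, the first such gap in the series, although each compound in the ordered run stays within the scatter of the next. Nothing measured on these compounds accounts for the size of this step or of that gap.

The compounds shown leave open whether the fluorine or its place on the phenyl carries the step, since a 4-fluorophenyl or a 2-chlorophenyl group would separate the two. They also leave open how an amine or a carboxylic acid on the phenyl would read in this assay in this series.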